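The source may report more compounds than this note shows. Statements on the series, on what has been measured and on what is new or still open speak of the compounds shown alone.

Measured so far:
- compound 1, `CC(C)=CCC/C(C)=C/CC/C(C)=C/CSc1ccccc1C(=O)NCC(=O)OCC#CCOc1no[n+]([O-])c1S(=O)(=O)c1ccccc1`: 7230 nM
- compound 2, `CC(C)=CCC/C(C)=C/CC/C(C)=C/CSc1ccccc1C(=O)N[C@@H](C)C(=O)OCCOCCOc1no[n+]([O-])c1S(=O)(=O)c1ccccc1`: 4210 nM

Working notes on the series. Of the compounds shown here, two have been measured in a functional assay on MDA-MB-231 cells (Homo sapiens) for cytotoxicity, read by MTT assay, with a stated time of 48 h; a lower number here means a stronger inhibitor, a higher number a weaker inhibitor. Compound 1 gives 7230 nM in this assay. Compound 2 gives 4210 nM in this assay, the lower of the two numbers, but the gap to compound 1 lies within the scatter of repeated measurements, so no order between the two can be read from these values.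

Compound 3, `CC(C)=CCC/C(C)=C/CC/C(C)=C/CSc1ccccc1C(=O)NCC(=O)OCCOCCOc1no[n+]([O-])c1S(=O)(=O)c1ccccc1`, has not been measured. It differs from compound 2 in one place:

hydrogen in place of methyl on a saturated chain carbon bound to an amide-type nitrogen and a carbonyl carbon

Compound 3 thus carries the same glycine-derived amide portion as compound 1, combined with the linker of compound 2. Among the compounds with values here, no measured pair isolates this change, so no step of known size exists for it. Both measured values sit close together, and the part of the molecule being changed is a small one; the expectation is therefore a step of no size beyond the scatter, if anything drifting toward the number of compound 1.

Compound 3 is expected to give 5200 nM in this assay, with a range of 2600 nM to 10400 nM, which corresponds to an estimated step of a 1.2-fold higher number from compound 2 to compound 3 (0.09 log units; within the scatter).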

Compound 3, half-maximal inhibitory concentration: 2410 nM
Compound 3: the middle estimate sits 2.2-fold (0.33 log units) above what was measured; the whole stated range lies above it.
By their numbers in this assay, from the lowest: compounds 3, 2 and 1 (each within the scatter of the next, the first and the last beyond it).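

Hydrogen in place of methyl on a saturated chain carbon bound to an amide-type nitrogen and a carbonyl carbon now has a step of known size, with the linker of compound 2 held constant: in this assay the step is a 1.7-fold lower number from compound 2 to compound 3 (0.24 log units; within the scatter). The methyl is therefore not required at this position for a value in this range, since compound 2 and compound 3 cannot be told apart in this assay, and the step gives no sign that this small group matters here. No measurement shown offers a reason for this result.

Open, going by these compounds, is whether a larger group on this carbon, such as an isopropyl, a benzyl or a hydroxymethyl, would leave the number within the scatter or move it beyond, as a single step from methyl to hydrogen says nothing about such groups. Also open is whether the same exchange of methyl and hydrogen gives a similar step with the linker of compound 1, as no such pair is available in the compounds shown.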